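A few compounds are considered here, and "the series" means these few. Any claim that something is new, unique, unknown or untested is made for them only; others in the source may bear on it.

Measured in an ADME assay on microsomes from liver (Homo sapiens) for metabolic stability; a higher number here means that the compound lasts longer, a lower number that the compound disappears faster:
- compound 1 `COc1cc(OCc2csc(-c3ccc(C(N)=O)cc3)n2)c2cc(-c3cn4nc(OC)sc4n3)oc2c1`: 1.38 h
- compound 2 `COc1cc(OCc2csc(-c3ccc(C(=O)O)cc3)n2)c2cc(-c3cn4nc(OC)sc4n3)oc2c1`: > 2 h, a limit of the assay

Compound 2 has no number, so its place is known only as the limit of > 2 h in this assay, at which 1 of the 2 values shown sits. Compound 3 `COc1cc(OCc2csc(-c3ccccc3)n2)c2cc(-c3cn4nc(OC)sc4n3)oc2c1` is not yet measured. It has hydrogen in place of carboxy on an aromatic carbon, para to a large group, so 4-carboxyphenyl becomes phenyl (hydrogen in place of carboxy on an aromatic carbon). Within the data shown here, the only measured step touching that carboxy is an at least 1.4-fold higher number from compound 1 to compound 2 (0.16 log units; that floor lies within the scatter). Among the measured compounds shown here, it gives a floor and no true size, and no measured step removes the group outright. Compound 1, which also lacks the carboxy, gives 1.38 h, and this is the closest anchor. In this assay the step is therefore loosely expected to be an at least 1.6-fold lower number from compound 2 to compound 3 (0.22 log units; that floor lies within the scatter). For compound 3 the estimated half-life is 1.2 h, with an expected range of 0.5 h to 2.5 h.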

Compound 3, half-life: 1.33 h
The estimate for compound 3 lay 1.1-fold (0.04 log units) below the measured number, and the stated range covers the measured number.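

In this assay, replacing carbamoyl with hydrogen gives a 1.0-fold lower number from compound 1 to compound 3 (0.02 log units; within the scatter), so at this position on the phenyl ring the two cannot be told apart, and the carbamoyl group shows no measurable effect on half-life. Replacing carboxy with hydrogen gives an at least 1.5-fold lower number from compound 2 to compound 3 (0.17 log units; that floor lies within the scatter), which adds a second floor to the earlier one but still no true size for the carboxy step. Compound 2 remains a limit of the assay, so both steps that involve it are bounds only: the limit of > 2 h in this assay, at which 1 of the 3 values shown sits.

As far as these compounds go, whether carboxy truly separates from hydrogen and carbamoyl beyond the scatter stays open, with no number for compound 2. Also open, from the compounds shown here alone, is how a methyl ester, an amine or a hydroxy group at this position would read in this assay.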